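Dimethylamino in place of acetyl: compound 1 to compound 4

The compounds below may be only part of what the source reports. "The series", "measured", "known", "first", "only" and "open" are said of these compounds alone.

Compound 1 `COc1cc(C)cc(-c2c(-c3ccnc(-c4ccc(C(C)=O)cc4)c3)cnn2CC#N)c1` reaches only a limit in a functional assay on PC-3 cells (Homo sapiens) for inhibition, read by sulforhodamine B assay, with a stated time of 48 h (a lower number here means that less compound is tolerated, a higher number that more compound is tolerated), where compound 1 gives > 100000 nM. Compound 2 `Cc1cc(O)cc(-c2nn(CC#N)cc2-c2ccnc(-c3ccc(Oc4ccccc4)cc3)c2)c1` gives 62000 nM in this assay. Compound 3 `Cc1cc(O)cc(-c2nn(CC#N)cc2-c2ccnc(-c3ccc(N(C)C)cc3)c2)c1` again ends at a limit, giving > 100000 nM in this assay. Compound 4 `COc1cc(C)cc(-c2c(-c3ccnc(-c4ccc(N(C)C)cc4)c3)cnn2CC#N)c1` differs from compound 1 by dimethylamino in place of acetyl on an aromatic carbon. Going by the values given here, the one measured step that bears on it, an at least 1.6-fold higher number from compound 2 to compound 3 (0.20 log units; that floor lies within the scatter), brings in dimethylamino for a different group and ends at the limit (the limit of > 100000 nM in this assay, at which 2 of the 3 values shown sit). No step shown moves the number downward beyond the scatter, so compound 4 is expected to remain at that limit, an expected step that the limit leaves unreadable from compound 1 to compound 4. The estimate for compound 4 in this assay is 150000 nM, between 60000 nM and 400000 nM.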

Compound 4, concentration lethal to 50% of the cells: > 100000 nM
Compound 4 ended at the assay's limit (the forecaster's own chance of this, stated with the estimate: 80%); the middle value does not contradict the limit.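

Compound 1 and compound 4 both end at a limit, so the step between them cannot be read: the limit of > 100000 nM in this assay, at which 3 of the 4 values shown sit.

The compounds shown leave open whether 4-acetylphenyl and 4-(dimethylamino)phenyl differ at all in this read-out.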